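This account rests on a few compounds, and the source may have more. Where it says the series, first, only, none or still open, it means among the compounds named here.

Working notes on the series in an ADME assay on L02 cells (Homo sapiens) for antiproliferative activity, read by MTT assay, with a stated time of 48 h; on this read-out lower numbers stand for stronger inhibition and higher numbers for weaker inhibition.

For the measured compounds named here, compound 3 `CCc1ccccc1-n1nncc1CN1C(=O)C2(C(C#N)=C(N)Oc3c(N)cc4nc5ccccc5nc4c32)c2ccccc21` is the one member of the set that yields a number: in this assay compound 3 gives 22900 nM. The other two values are limits. Compound 1 `Cc1ccc(-n2nncc2CN2C(=O)C3(C(C#N)=C(N)Oc4c3c3nc5ccccc5nc3c3ccccc43)c3ccccc32)cc1C` reaches only the limit > 50000 nM in this assay. Compound 2 `N#CC1=C(N)Oc2c(c3nc4ccccc4nc3c3ccccc23)C12C(=O)N(Cc1cnnn1-c1cc(Cl)ccc1Cl)c1ccccc12` likewise sits at the limit > 50000 nM in this assay. Going by the values given here, the sole step that can be compared, a step that the two limits leave unreadable from compound 1 to compound 2, therefore carries no readable size, since the limit of > 50000 nM in this assay, at which 2 of the 3 values shown sit, holds both ends of it.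

Compound 4 `Cc1ccc(C)c(-n2nncc2CN2C(=O)C3(C(C#N)=C(N)Oc4c(N)cc5nc6ccccc6nc5c43)c3ccccc32)c1` is the next member. It differs from compound 3 as 2,5-dimethylphenyl in place of 2-ethylphenyl on an aromatic nitrogen; the exchange keeps the same atoms joined differently, with no change in donor or acceptor count and no change in charge.

Among the compounds with values here, no measured step shows what swapping one such alkylphenyl group for another does here, so nothing in the data argues for a shift beyond the usual scatter. The working expectation is that compound 4 stays close to compound 3, that is, a step of about a 1.1-fold higher number from compound 3 to compound 4 (0.04 log units; within the scatter) is expected. For compound 4 the estimate in this assay is 25000 nM, expected to lie between 9000 nM and 50000 nM, with a real chance that the assay reports only a limit, as it did for compounds 1 and 2.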

Compound 4, half-maximal inhibitory concentration: > 50000 nM
Compound 4: only a limit was reported; the forecaster's own chance of this, stated with the estimate: 30%; middle value at least 2.0-fold (0.30 log units) from the limit.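

In this assay, for the compounds shown here, 2,5-dimethylphenyl in place of 2-ethylphenyl on an aromatic nitrogen gives an at least 2.1-fold higher number from compound 3 to compound 4 (0.33 log units; beyond the scatter), so on the core shared by these two compounds an exchange that keeps the same atoms, joined differently, produces a step beyond the scatter, the first readable step at this position, since the step from compound 1 to compound 2 cannot be read. Compound 4 gives > 50000 nM, which is a limit and not a number, so the step has a readable lower size but no upper one. Compound 3 remains the only member of the set with a number, and 2-ethylphenyl is the only group on this nitrogen that goes with one, while the other three compounds share the same ceiling: the limit of > 50000 nM in this assay, at which 3 of the 4 values shown sit.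

The compounds shown leave open whether the ethyl group of compound 3 or the pair of methyl groups of compound 4 accounts for the step, which 2-methylphenyl or plain phenyl on the same nitrogen could separate. Also open, as far as these compounds go, is whether a longer chain such as 2-propylphenyl, or a phenyl carrying an amine or a carboxylic acid, would give a number in this assay or another limit.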